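Changing the aryl group on the ring nitrogen

The compounds below may be only part of what the source reports. "The series", "measured", "known", "first", "only" and "open" are said of these compounds alone.

Compound 1 `Cc1ccc(N2CCN(CC(=O)N(c3ccccc3)c3ccccc3)CC2)cc1` gives > 20 mg/kg in this assay, a limit rather than a number.
Compound 2 `COc1ccccc1N1CCN(CC(=O)N(c2ccccc2)c2ccccc2)CC1` gives 8.2 mg/kg.
Compound 3 `O=C(CN1CCN(c2ccc(Cl)c(Cl)c2)CC1)N(c1ccccc1)c1ccccc1` gives 24 mg/kg.

In a functional assay on the whole organism (strain Swiss albino) for inhibition, with Mus musculus as the target, with stated times of 10 min, 5 min and 20 min (on this read-out higher numbers stand for an effect only at larger amounts of compound and lower numbers for an effect already at smaller amounts), compound 1 reaches only a limit of the assay and no number. Compound 2 gives the lowest of the two numbers in this assay, and its nearest neighbour is compound 3, reached by a 2.9-fold higher number from compound 2 to compound 3 (0.47 log units; beyond the scatter). The step of an at least 2.4-fold lower number from compound 1 to compound 2 (0.38 log units; beyond the scatter) points the same way, while the step that the limit leaves unreadable from compound 1 to compound 3 cannot be sized because of the limit of > 20 mg/kg in this assay, at which 1 of the 3 values shown sits.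

Compound 4 `O=C(CN1CCN(c2ccc([N+](=O)[O-])cc2)CC1)N(c1ccccc1)c1ccccc1` has not yet been measured in this assay. It differs from compound 2 in one place: 4-nitrophenyl in place of 2-methoxyphenyl on an amine nitrogen in a ring. Both measured steps that change the aryl group on the ring nitrogen bear on this change, and in both of them the 2-methoxyphenyl compound carries the lower number, the other aryl groups the higher. For compound 4 a modestly higher number is therefore expected, a 2.4-fold higher number from compound 2 to compound 4 (0.39 log units; beyond the scatter). Compound 4 is estimated at 20 mg/kg, with a range from 9 mg/kg to 45 mg/kg, and a fair chance that only a limit is reported.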

Compound 4, dose for half-maximal effect: 30 mg/kg
The estimate for compound 4 lay 1.5-fold (0.18 log units) below the measured number; measured number inside the range.
By their numbers in this assay, from the lowest: compound 2; then compounds 3 and 4 (each within the scatter of the next).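

With a 3.7-fold higher number from compound 2 to compound 4 (0.56 log units; beyond the scatter) in this assay, the 4-nitrophenyl group becomes a further aryl group on the ring nitrogen that gives a higher number than the 2-methoxyphenyl group, so the low number of compound 2 now stands apart from two measured numbers. With a 1.3-fold higher number from compound 3 to compound 4 (0.10 log units; within the scatter), the 4-nitrophenyl and 3,4-dichlorophenyl groups cannot be told apart at this position. The steps from compound 1 cannot be read because compound 1 gives only a limit: the limit of > 20 mg/kg in this assay, at which 1 of the 4 values shown sits.

The compounds shown leave open whether a 4-methoxyphenyl, a 2-ethoxyphenyl or an unsubstituted phenyl group on the ring nitrogen would share the number of compound 2. They also leave open whether that number follows the methoxy group itself or its place in the 2-methoxyphenyl group.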